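Cyclopentyl Amide in Place of Cyanophenyl: Cytotoxicity Outlook

The compounds below may be only part of what the source reports. "The series", "measured", "known", "first", "only" and "open" are said of these compounds alone.

Compound 3 `COc1ccc(-c2cnc(NC(=O)c3ccccc3C#N)n2C)cc1` was tested in a toxicity assay on THP-1 cells (Homo sapiens) for inhibition; on this read-out higher numbers stand for lower toxicity in this test and lower numbers for higher toxicity in this test. In this assay compound 3 reaches only the limit > 100000 nM. Compound 1 `COc1ccc(-c2cnc(NC(=O)c3cnc[nH]3)n2C)cc1` likewise sits at the limit > 100000 nM. Compound 2 `COc1ccc(-c2cnc(NC(=O)c3ccccc3C)n2C)cc1` also stands at the limit > 100000 nM. Because all three values share (the limit of > 100000 nM in this assay, at which 3 of the 3 values shown sit), the steps a step that the two limits leave unreadable from compound 1 to compound 2, a step that the two limits leave unreadable from compound 1 to compound 3 and a step that the two limits leave unreadable from compound 2 to compound 3 cannot be sized. Compound 4 `COc1ccc(-c2cnc(NC(=O)C3CCCC3)n2C)cc1` differs from compound 3 by cyclopentyl in place of 2-cyanophenyl on a carbonyl carbon. Within the data shown here, no measured step separates two real numbers, so none gives a readable size for this change; the expectation rests only on the three compounds sitting at the same limit. Compound 4 is therefore estimated at 100000 nM, expected between 40000 nM and 300000 nM. The step of a number no higher from compound 3 to compound 4 (the limit leaves the size open) is thus expected to show no change beyond the scatter.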

Compound 4, half-maximal cytotoxic concentration: > 100000 nM
Compound 4 ended at the assay's limit; the forecaster's own chance of this, stated with the estimate: 85%; the middle value lies on the limit itself.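

No step from compound 1, compound 2 or compound 3 to compound 4 can be read in this assay: the limit of > 100000 nM in this assay, at which 4 of the 4 values shown sit.

The compounds shown leave open whether the groups on the carbonyl carbon differ at all in cytotoxicity.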